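Methyltetrazolyl in Place of Pyridinyl on a Shared Core

A few compounds are considered here, and "the series" means these few. Any claim that something is new, unique, unknown or untested is made for them only; others in the source may bear on it.

Two measured compounds share one core and differ only in the aromatic group attached to it. Compound 1 `CN1CCC(c2cn(-c3ccc(F)cc3)c3ccc(-c4cnn(C)c4)cc23)CC1` carries a 1-methyl-1H-pyrazol-4-yl group, and in an in vitro assay on BHK cells for displacement of a labelled ligand from Alpha-1A adrenergic receptor (Bos taurus), read by scintillation counting, with a stated time of 20 min (on this read-out higher numbers stand for weaker inhibition and lower numbers for stronger inhibition), compound 1 gives 2.7 nM. Within the data shown here, compound 2 `CN1CCC(c2cn(-c3ccc(F)cc3)c3ccc(-c4ccncc4)cc23)CC1` carries a pyridin-4-yl group at the same place, and in this assay compound 2 gives 10 nM, the higher of the two numbers; the only measured step is a 3.7-fold higher number from compound 1 to compound 2 (0.57 log units; beyond the scatter).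

Compound 3 `CN1CCC(c2cn(-c3ccc(F)cc3)c3ccc(-c4nnn(C)n4)cc23)CC1` has not yet been measured. It differs from compound 2 in one place: 2-methyl-2H-tetrazol-5-yl in place of pyridin-4-yl on an aromatic carbon. Among the measured compounds shown here, the single measured step that bears on this position, a 3.7-fold higher number from compound 1 to compound 2 (0.57 log units; beyond the scatter), shows that exchanging one aromatic group for another at this place moves the number modestly. The entering 2-methyl-2H-tetrazol-5-yl group, like the 1-methyl-1H-pyrazol-4-yl group of compound 1, is a methylated azole, so the author expects a modest step back toward the number of compound 1, a 2.0-fold lower number from compound 2 to compound 3 (0.30 log units; within the scatter). Compound 3 is therefore estimated at 5 nM, with an expected range from 1.5 nM to 20 nM.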

Compound 3, inhibition constant: 0.28 nM
Compound 3: middle estimate off by 18-fold (1.25 log units), on the high side; measured number outside the range, below it.
By their numbers in this assay, from the lowest: compound 3; then compound 1; then compound 2.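

Among these compounds, at this aromatic carbon of the shared core, the change to 2-methyl-2H-tetrazol-5-yl in this assay produces a large step (a 36-fold lower number from compound 2 to compound 3 (1.55 log units; beyond the scatter)), showing that the position can move the number much further than the one earlier step suggested. Nor do the two methylated azoles give matching numbers, since the change from 1-methyl-1H-pyrazol-4-yl to the tetrazole still gives a step beyond the scatter (a 9.6-fold lower number from compound 1 to compound 3 (0.98 log units; beyond the scatter)), so being a methylated azole does not by itself set the number at this place. No measurement is available here that accounts for the low number of compound 3.

Going by these compounds, what remains open is whether that number depends on the tetrazole ring, on its methyl group or on where the methyl sits, a question that 2H-tetrazol-5-yl, 2-ethyl-2H-tetrazol-5-yl or 1-methyl-1H-tetrazol-5-yl at the same carbon would address. On these data alone, it is also open how far the trend extends to other groups at this place, such as a carboxylic acid, an amine or a longer chain on the tetrazole.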